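From open chain to ring: estimating compound 4

The source may report more compounds than this note shows. Statements on the series, on what has been measured and on what is new or still open speak of the compounds shown alone.

Measured in a functional assay on A549 cells (Homo sapiens) for antiproliferative activity; on this read-out higher numbers stand for weaker inhibition of growth and lower numbers for stronger inhibition of growth:
Compound 1 `CC/C=C\[C@H](C)[C@H](OC(N)=O)[C@@H](C)[C@H](O)[C@@H](C)C/C(C)=C\[C@H](C)[C@@H](O)[C@@H](C)/C=C\[C@@H](O)C[C@H](O)[C@H](C)CO`: 3000 nM
Compound 2 `CC/C=C\[C@H](C)[C@H](OC(N)=O)[C@@H](C)[C@H](O)[C@@H](C)C/C(C)=C\[C@H](C)[C@@H](O)[C@@H](C)/C=C\[C@@H](O)C[C@H]1CCC(=O)O1`: 46 nM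
Compound 3 `CC/C=C\[C@H](C)[C@H](OC(N)=O)[C@@H](C)[C@H](O)[C@@H](C)C/C(C)=C\[C@H](C)[C@@H](O)[C@@H](C)/C=C\[C@@H](O)C[C@H](O)[C@H](C)C[C@H](C)C(=O)OC`: 4000 nM

Compound 3, at 4000 nM, sits level with compound 1, as a 1.3-fold higher number from compound 1 to compound 3 (0.12 log units; within the scatter) shows, and far from compound 2, as an 87-fold higher number from compound 2 to compound 3 (1.94 log units; beyond the scatter) shows. Compound 4 `CC/C=C\[C@H](C)[C@H](OC(N)=O)[C@@H](C)[C@H](O)[C@@H](C)C/C(C)=C\[C@H](C)[C@@H](O)[C@@H](C)/C=C\[C@@H](O)C[C@@H]1OC(=O)NC[C@H]1C` carries a group of 8 heavy atoms (5 carbon, 1 nitrogen, 2 oxygen; one six-membered non-aromatic ring with 2 hetero atoms) in place of a group of 11 heavy atoms (8 carbon, 3 oxygen; no ring), on a saturated chain carbon, two bonds along the chain from a double-bonded chain carbon and an oxygen on a saturated carbon. The two ringless compounds agree, whereas the five-membered ring of compound 2 gave a 65-fold lower number from compound 1 to compound 2 (1.81 log units; beyond the scatter). Within the data shown here, compound 4 has a six-membered ring instead, and no compound with that ring has been measured, so only part of that large step is expected to carry over in this assay. The expected change is a lower number, namely a 13-fold lower number from compound 3 to compound 4 (1.12 log units; beyond the scatter). Compound 4 is estimated at 300 nM, with an expected range of 60 nM to 2000 nM.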

Compound 4, concentration for 50% growth inhibition: 520 nM
Compound 4: the middle estimate sits 1.7-fold (0.24 log units) below what was measured; low and high end bracket the measured number.
By their numbers in this assay, from the lowest: compound 2; then compound 4; then compounds 1 and 3 (each within the scatter of the next).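

In this assay a six-membered ring also lowers the number relative to the open chains, with a 7.7-fold lower number from compound 3 to compound 4 (0.89 log units; beyond the scatter) and a 5.8-fold lower number from compound 1 to compound 4 (0.76 log units; beyond the scatter), so at this position the gain is not confined to the five-membered ring of compound 2. The two rings are not equivalent, however, as an 11-fold higher number from compound 2 to compound 4 (1.05 log units; beyond the scatter) shows. No evidence at hand accounts for these differences. The rings differ in size and in their atoms, so the compounds shown do not separate these two changes. From the compounds shown here alone, it remains open where a six-membered ring of carbon and oxygen alone, without nitrogen, would fall.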